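Piperazine series: ethoxyphenyl for methyl, second core

The source may hold more compounds than are shown below. What is called first, only, known or untested is meant among the compounds shown, and "the series" means these compounds.

Of the compounds shown here, three have been measured in a functional assay on MCF7 cells (Homo sapiens) for cytotoxicity, read by MTT assay, with a stated time of 24 h; on this read-out lower numbers stand for stronger inhibition and higher numbers for weaker inhibition. Compound 1 `CCOc1ccccc1N1CCN(C(=S)SCc2nc3cc(Cl)c(Cl)cc3[nH]2)CC1` gives 16200 nM. Where compound 1 carries a 2-ethoxyphenyl on the ring nitrogen, compound 2 `CN1CCN(C(=S)SCc2nc3cc(Cl)c(Cl)cc3[nH]2)CC1` carries a methyl, and compound 2 gives 30500 nM. The change between them is 2-ethoxyphenyl in place of methyl on an amine nitrogen in a ring, and it made a step of a 1.9-fold lower number from compound 2 to compound 1 (0.27 log units; within the scatter).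

Compound 3 `CN1CCN(CCCSc2nc3cc(Cl)ccc3[nH]2)CC1` has a different core and gives 13900 nM. How the core of compound 3 differs from that of compound 2 is not broken down here. The values show that compound 2 gives a higher number than compound 3, beyond the scatter, while compound 1 and compound 3 lie within the scatter of each other.

Compound 4 `CCOc1ccccc1N1CCN(CCCSc2nc3cc(Cl)ccc3[nH]2)CC1` is not yet measured. It differs from compound 3 by 2-ethoxyphenyl in place of methyl on an amine nitrogen in a ring, the same change as from compound 2 to compound 1, at the same place in the same words. Within the data shown here, only one earlier instance exists, and it lay within the scatter, so the expectation rests on that single step and on the value of compound 3. For compound 4 a step of a 1.7-fold lower number from compound 3 to compound 4 (0.24 log units; within the scatter) is expected, beside the earlier step of a 1.9-fold lower number from compound 2 to compound 1 (0.27 log units; within the scatter), on the assumption that the change behaves alike on this core. Compound 4 is therefore estimated at 8000 nM, with a range from 3500 nM to 20000 nM.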

Compound 4, half-maximal inhibitory concentration: 27700 nM
Beside the measured number, compound 4's estimate is 3.5-fold (0.54 log units) below it, and the stated range ends below it.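

In this assay, 2-ethoxyphenyl in place of methyl on an amine nitrogen in a ring gives a 2.0-fold higher number from compound 3 to compound 4 (0.30 log units; within the scatter), which does not repeat the direction of the earlier step, and the two steps differ by more than their scatter: the same change on two cores in this assay, a 1.9-fold lower number (0.27 log units; within the scatter) from compound 2 to compound 1 and a 2.0-fold higher number (0.30 log units; within the scatter) from compound 3 to compound 4, 3.8-fold (0.57 log units) apart, beyond the scatter of two such steps. Each step taken alone lies within the scatter, so neither one establishes an effect of the change on its own core, and the evidence for a core dependence rests only on the gap between these two pairs. This shows that, within these four compounds, the step seen on one core is a poor guide to the step on the other, but it does not show which feature of the two cores goes with the difference, nor does it give a rule for other cores in the series.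

On these data alone, it remains open whether a plain phenyl, a benzyl or an ethyl group on the same ring nitrogen would also behave differently on the two cores. As far as these compounds go, it also remains open whether the gap between the two steps would persist on a core like that of compound 3 with a shorter chain or with a second chlorine on the ring system.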